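The source may hold more compounds than are shown below. What is called first, only, known or untested is meant among the compounds shown, and "the series" means these compounds.

Measured compounds:
Compound 1 `Cc1cc(NC(=O)Nc2ccc(C)c(Cl)c2)c2ccccc2n1`; in an ADME assay on HEK293 cells (Homo sapiens) for cytotoxicity, with a stated time of 72 h (a higher number here means that more compound is needed for the effect, a lower number that less compound is needed), compound 1 gives > 25000 nM, which is a limit of the assay.
Compound 2 `COc1ccc(NC(=O)Nc2cc(C)nc3ccccc23)cc1`; compound 2 gives > 25000 nM, again a limit.
Compound 3 `COc1ccc(NC(=O)Nc2cc(C)nc3ccccc23)cc1F`; compound 3 gives > 25000 nM, also a limit.

Compound 2 therefore stands only at a limit, as do the two other values shown (the limit of > 25000 nM in this assay, at which 3 of the 3 values shown sit). For the measured compounds named here, the single one-place step, a step that the two limits leave unreadable from compound 2 to compound 3, cannot be read since both its ends sit at the limit of > 25000 nM in this assay, at which 3 of the 3 values shown sit.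

Compound 4 `COC(=O)c1ccc(NC(=O)Nc2cc(C)nc3ccccc23)cc1` differs from compound 2 by methoxycarbonyl in place of methoxy on an aromatic carbon. Going by the values given here, no measured step bears on this change; the only comparable step is unreadable. In this assay no step beyond the scatter is expected, so the estimated step is a step that the limit leaves unreadable from compound 2 to compound 4. Compound 4 is expected at 40000 nM, within 15000 nM to 120000 nM, most likely reported again as a limit.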

Compound 4, half-maximal effective concentration: 15000 nM
The estimate for compound 4 lay 2.7-fold (0.43 log units) above the measured number; the range from low to high includes it.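

In this assay methoxycarbonyl in place of methoxy gives an at least 1.6-fold lower number from compound 2 to compound 4 (0.22 log units; that floor lies within the scatter) on this aromatic carbon, para to a large group. Compound 4 is the only compound shown with a number rather than a limit, so a change at this place can bring the read-out into range, although the full size of the step stays unknown. The other steps cannot be read: the limit of > 25000 nM in this assay, at which 3 of the 4 values shown sit.

From the compounds shown here alone, whether the ester as a whole matters here stays open. A carboxylic acid or a primary amide at this place would test that.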